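The source may hold more compounds than are shown below. What is called first, only, known or untested is meant among the compounds shown, and "the series" means these compounds.

Measured so far in an ADME assay on GES1 cells (Homo sapiens) for cytotoxicity, read by MTT assay, with a stated time of 24 h; a higher number here means that more compound is tolerated, a lower number that less compound is tolerated:
Compound 1, `O=c1[nH]cc(S(=O)(=O)Nc2ccccc2-c2cn(-c3ccccc3)nn2)c(=O)[nH]1`: compound 1 gives > 100000 nM, which is a limit of the assay rather than a number.
Compound 2, `O=c1[nH]cc(S(=O)(=O)Nc2ccccc2-c2cn(-c3cccc(Cl)c3)nn2)c(=O)[nH]1`: compound 2 gives > 100000 nM, again a limit.
Compound 3, `Cc1ccccc1-n1cc(-c2cccc(NS(=O)(=O)c3c[nH]c(=O)[nH]c3=O)c2)nn1`: compound 3 gives 21500 nM.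

Compound 3 is therefore the only one of the three with an actual number in this assay; the two others sit at the limit of > 100000 nM in this assay, at which 2 of the 3 values shown sit. Among the measured compounds shown here, the one step between measured compounds that differ in a single place, a step that the two limits leave unreadable from compound 1 to compound 2, a chloro in place of hydrogen on an aromatic carbon, runs between two limits and so gives no readable size.

Compound 4, `O=c1[nH]cc(S(=O)(=O)Nc2cccc(-c3cn(-c4ccccc4F)nn3)c2)c(=O)[nH]1`, differs from compound 3 by fluoro in place of methyl on an aromatic carbon, ortho to a large group, or, cut one bond further out, 2-methylphenyl to 2-fluorophenyl. For the measured compounds named here, no measured step bears on a change of this kind, and the single step that was measured offers no size at all. With nothing to point to a shift in either direction, the step from compound 3 to compound 4 in this assay is expected to stay within the scatter, so the estimated step is a 1.2-fold higher number from compound 3 to compound 4 (0.07 log units; within the scatter). Compound 4 is accordingly estimated at 25000 nM, with a range from 8000 nM to 100000 nM.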

Compound 4, half-maximal cytotoxic concentration: "not toxic" (no number reported)
Nothing numeric was reported for compound 4; the estimate stays without a comparison.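

In this assay, among the compounds shown here, compound 4 gives "not toxic" (no number reported), a report without a number, so no step from compound 3 to compound 4 can be read. What the compounds shown leave open is how much, if at all, fluoro in place of methyl changes the tolerated concentration, and where the compounds without a number truly lie: the limit of > 100000 nM in this assay, at which 2 of the 4 values shown sit.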